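A halogen swap from compound 2 to compound 3

A few compounds are considered here, and "the series" means these few. Any claim that something is new, unique, unknown or untested is made for them only; others in the source may bear on it.

Compound 1 `COc1cc(/C=C2\CN(C)C/C(=C\c3ccccc3F)C2=O)cc(OC)c1OC`: 4340 nM
Compound 2 `CN1C/C(=C\c2cccc([N+](=O)[O-])c2)C(=O)/C(=C/c2ccccc2F)C1`: 3890 nM

Both were tested in a functional assay on K562 cells (Homo sapiens) for cytotoxicity, read by MTT assay, with a stated time of 24 h (on this read-out higher numbers stand for weaker inhibition and lower numbers for stronger inhibition), and the numbers for compound 1 and compound 2 lie within the usual scatter of each other. Compound 3 `CN1C/C(=C\c2ccc(Br)cc2)C(=O)/C(=C/c2cccc([N+](=O)[O-])c2)C1` changes one group of compound 2: 4-bromophenyl in place of 2-fluorophenyl on a double-bonded chain carbon bound to a double-bonded ring carbon, on a double-bonded chain carbon bound to a double-bonded ring carbon. Going by the values given here, no measured step shows what this swap does, and the only guide is that compound 1 at 4340 nM and compound 2 at 3890 nM sit close together. The expected change is a 1.1-fold lower number from compound 2 to compound 3 (0.05 log units; within the scatter), estimated to stay within the scatter, in no clear direction. For compound 3 the estimated value is 3500 nM, with an expected range of 1500 nM to 8000 nM.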

Compound 3, half-maximal inhibitory concentration: > 20000 nM
Compound 3: only a limit was reported (the forecaster's own chance of this, stated with the estimate: 3%); middle value at least 5.7-fold (0.75 log units) from the limit.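

This position is sensitive to its group. In this assay, 4-bromophenyl in place of 2-fluorophenyl gives an at least 5.1-fold higher number from compound 2 to compound 3 (0.71 log units; beyond the scatter). Compound 1 and compound 2 both carry 2-fluorophenyl and lie within the scatter of each other, so they gave no hint of this, and compound 3 has only a limit, not a number: the limit of > 20000 nM in this assay, at which 1 of the 3 values shown sits.

On these data alone, the swap changes the halogen and its place on the ring together, so 2-bromophenyl and 4-fluorophenyl remain open. Also open, as far as these compounds go, is how a phenyl group bearing an amine or a carboxylic acid would behave here.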